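A few compounds are considered here, and "the series" means these few. Any claim that something is new, unique, unknown or untested is made for them only; others in the source may bear on it.

Working notes, series summary.

Measured compounds in an ADME assay on cells (Hepatocyte, Homo sapiens) for metabolic stability, with a stated time of 30 min; a higher number here means that more of the compound is left, a lower number that less of the compound is left:

- compound 1 `O=c1cc(N2CCN(CC3CCC(O)CC3)CC2)sc2c([N+](=O)[O-])cc(C(F)(F)F)cc12`: compound 1 gives 72.7%
- compound 2 `CC(=O)NC1CCC(CN2CCN(c3cc(=O)c4cc(C(F)(F)F)cc([N+](=O)[O-])c4s3)CC2)CC1`: compound 2 gives 86.8%
- compound 3 `COc1ccc(C(=O)OC2CCC(CN3CCN(c4cc(=O)c5cc(C(F)(F)F)cc([N+](=O)[O-])c5s4)CC3)CC2)cc1`: compound 3 gives 12.2%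

Compound 3 stands lowest of the three numbers in this assay; the nearest is compound 1, a number 60.5 percentage points lower from compound 1 to compound 3 (beyond the scatter), and the furthest is compound 2, a number 74.6 percentage points lower from compound 2 to compound 3 (beyond the scatter). Both of these steps are beyond the scatter and large, and both lead from a hydroxy or acetamido group on the saturated ring carbon to the ((4-methoxyphenyl)carbonyl)oxy group of compound 3. The smaller step between compound 1 and compound 2, a number 14.1 percentage points higher from compound 1 to compound 2 (beyond the scatter), is modest.

Compound 4 `O=c1cc(N2CCN(CC3CCC(NS(=O)(=O)c4ccccc4)CC3)CC2)sc2c([N+](=O)[O-])cc(C(F)(F)F)cc12` is not yet measured. Its difference from compound 3: (phenylsulfonyl)amino in place of ((4-methoxyphenyl)carbonyl)oxy on a saturated ring carbon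

The two steps that bear on this change are those into compound 3 itself, since compound 4 reverses the entry of the ((4-methoxyphenyl)carbonyl)oxy group and installs a group that, like the acetamido of compound 2, carries one hydrogen-bond donor. For the measured compounds named here, no measured step covers a (phenylsulfonyl)amino group, so the size of the reversal is uncertain. A step upward in this assay is expected for compound 4, a number 45.8 percentage points higher from compound 3 to compound 4 (beyond the scatter), beyond the scatter but short of a full return to the level of compound 2. The estimate for compound 4 is 58%, with a range from 30% to 85%.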

Compound 4, percent of the compound remaining: 90.8%
The estimate for compound 4 lay 32.8 percentage points below the measured number; measured number above the stated range.
By their numbers in this assay, from the lowest: compound 3; then compound 1; then compounds 2 and 4 (each within the scatter of the next).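

At this saturated ring carbon, in this assay, the exchange of ((4-methoxyphenyl)carbonyl)oxy for (phenylsulfonyl)amino gives a number 78.6 percentage points higher from compound 3 to compound 4 (beyond the scatter) and so shows that a group with a six-membered aromatic ring can stand here with much of the compound left, which means that this ring alone does not go with the low number of compound 3. On the amine nitrogen, phenylsulfonyl in place of acetyl gives a number 4 percentage points higher from compound 2 to compound 4 (within the scatter) in this read-out, so two quite different groups on that nitrogen give numbers that cannot be told apart. Against the hydroxy group, the change gives a number 18.1 percentage points higher from compound 1 to compound 4 (beyond the scatter) and, with compound 2, places both compounds with a nitrogen on this carbon above compound 1 and compound 3, the two with an oxygen there, a pattern that no compound shown goes against, though it rests on only four compounds. Nothing at hand explains any of these differences.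

The compounds shown leave open whether the low number of compound 3 goes with its ester oxygen or with the 4-methoxyphenyl group, a question that (4-methoxyphenyl)carbonyl on the amine nitrogen or a plain acetyl on the oxygen would separate. Going by these compounds, how a free amine or a carboxylic acid on this saturated ring carbon would read also stays open.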